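The source may hold more compounds than are shown below. What is called first, only, known or untested is meant among the compounds shown, and "the series" means these compounds.

Measured so far in a functional assay on HT-1080 cells (Homo sapiens) for cytotoxicity, read by MTT assay, with a stated time of 72 h; a higher number here means a weaker inhibitor, a lower number a stronger inhibitor:

compound 1 `COc1ccc(C(=O)CCc2c(OC)cc(O)cc2OC)cc1` — compound 1 returns only the assay limit, > 100000 nM
compound 2 `COc1ccc(CCC(=O)c2ccc(O)cc2)c(O)c1` — compound 2 returns only the assay limit, > 100000 nM
compound 3 `O=C(CCc1ccc(O)cc1O)c1ccc(O)cc1` — compound 3 returns only the assay limit, > 100000 nM

None of the three gives a number in this assay; all sit at the limit of > 100000 nM in this assay, at which 3 of the 3 values shown sit. Among the measured compounds shown here, the one single-point change in the set, (hydrogen in place of methyl on an oxygen on an aromatic ring), therefore yields a step that the two limits leave unreadable from compound 2 to compound 3, and nothing can be said of its direction or size.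

Compound 4 `COc1cc(O)cc(OC)c1CCC(=O)c1ccc(O)cc1` is unmeasured. It differs from compound 1 by hydrogen in place of methyl on an oxygen on an aromatic ring, the same kind of change as that from compound 2 to compound 3; the place lines of both are word for word the same, so it is taken as the same change. How the core of compound 1 differs from that of compound 2 is not broken down here.

With every value in the set a limit, the expected step from compound 1 to compound 4 in this assay is a step that the limit leaves unreadable from compound 1 to compound 4, resting on (the limit of > 100000 nM in this assay, at which 3 of the 3 values shown sit). Compound 4 is expected at 150000 nM in this assay, estimated between 50000 nM and 500000 nM, most likely reported again only as a limit.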

Compound 4, half-maximal inhibitory concentration: 67200 nM
Estimate against measurement, compound 4: 2.2-fold (0.35 log units) above; measured number inside the range.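

In this assay, methoxy to hydroxy on the core of compound 1 gives an at least 1.4-fold lower number from compound 1 to compound 4 (0.17 log units; that floor lies within the scatter), so the step is known only as a floor and its true size stays unfixed. The same change on the core of compound 2 cannot be read because both of its ends are limits: the limit of > 100000 nM in this assay, at which 3 of the 4 values shown sit. The series therefore holds one floor and one unreadable step for this change, which shows neither agreement nor disagreement between the two cores, and the step seen on the core of compound 1 cannot be said to carry over to the core of compound 2.

The compounds shown leave open how either core responds when the oxygen on the aromatic ring carries something other than methyl or hydrogen, such as ethyl or a longer chain ending in an amine. Also open, going by these compounds, is whether a carboxylic acid in place of the hydroxy would give a number on either core in this assay.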